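Swapping the side chain of compound 2

The source may hold more compounds than are shown below. What is called first, only, known or untested is meant among the compounds shown, and "the series" means these compounds.

In a physicochemical assay for lipophilicity, using the shake flask method, in phosphate buffer, measured as octanol-water partition, with a stated time of 30 min, at pH 7.4 (on this read-out lower numbers stand for lower lipophilicity and higher numbers for higher lipophilicity), compound 2 (`COCCC(=O)Nc1cnc(NCc2c(F)ccc3c2CCO3)n2cnnc12`) gives 1.4 and stands lowest of three, with compound 3 (`CN(C)Cc1ccc(C(=O)Nc2cnc(NCc3c(F)ccc4c3CCO4)n3cnnc23)cc1`) at 1.8 and compound 1 (`Fc1ccc2c(c1CNc1ncc(Oc3ccccc3)c3nncn13)CCO2`) highest at 3.5 on this scale. Compound 4 (`CN(C(=O)c1ccccc1)c1cnc(NCc2c(F)ccc3c2CCO3)n2cnnc12`), still unmeasured, carries benzoyl(methyl)amino in place of ((2-methoxyethyl)carbonyl)amino on an aromatic carbon. For the measured compounds named here, two measured steps bear on this change. A large step at that same carbon was a number 2.10 log units lower from compound 1 to compound 2 (beyond the scatter) when ((2-methoxyethyl)carbonyl)amino replaced phenoxy. A modest one, on the carbonyl carbon, was a number 0.40 log units higher from compound 2 to compound 3 (beyond the scatter) when 4-((dimethylamino)methyl)phenyl replaced 2-methoxyethyl. A rise in this assay is therefore expected, somewhat beyond that modest step, at a number 1.00 log units higher from compound 2 to compound 4 (beyond the scatter) by estimate. For compound 4 the estimated value is 2.4 within a range from 1.9 to 3 in this measurement.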

Compound 4, distribution coefficient: 2.4
Compound 4: middle estimate and measured number agree at the digits printed; the measured number falls inside the stated range.
By their numbers in this assay, from the lowest: compound 2; then compound 3; then compound 4; then compound 1.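

In this assay, benzoyl(methyl)amino on this aromatic carbon gives a number 1.00 log units higher from compound 2 to compound 4 (beyond the scatter) and, measured against phenoxy at the same carbon, a number 1.10 log units lower from compound 1 to compound 4 (beyond the scatter) on the same scale. Of the three groups compared on this carbon, benzoyl(methyl)amino therefore gives the middle number. The change brings in a six-membered aromatic ring of carbon only and removes the hydrogen-bond donor together, so this step cannot separate the two. No measurement here gives a cause for either step. Still open, as far as these compounds go, is where a simple amine on this carbon, or a longer chain on the carbonyl, would fall.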